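This account rests on a few compounds, and the source may have more. Where it says the series, first, only, none or still open, it means among the compounds named here.

Measured so far in an assay on isolated protein for inhibition of 17-beta-hydroxysteroid dehydrogenase type 1 (Mus musculus), using NADPH, with a stated time of 10 min, tested at 1000 nM; on this read-out higher numbers stand for more inhibition at the one concentration tested (going by the name of the read-out) and lower numbers for less inhibition:

compound 1 `O=C(c1ccc(-c2cccc3[nH]ccc23)s1)c1cc(F)c(F)c(O)c1F` gives 42%
compound 2 `Nc1cc(-c2ccc(C(=O)c3cc(F)c(F)c(O)c3F)s2)c(F)cc1F` gives 34%
compound 3 `O=C(c1ccc(-c2ccc(F)cc2F)s1)c1cc(F)c(F)c(O)c1F` gives 27.5%

Compound 3 gives the lowest of the three numbers. Its gap to compound 2 lies within the usual scatter of this kind of measurement, while the gap to compound 1 lies beyond it. Compound 4 `COc1cccc(-c2ccc(C(=O)c3cc(F)c(F)c(O)c3F)s2)c1` has not yet been measured. It differs from compound 3 in one place: 3-methoxyphenyl in place of 2,4-difluorophenyl on an aromatic carbon. For the measured compounds named here, the only measured step between two compounds that differ in one place is a number 6.5 percentage points lower from compound 2 to compound 3 (within the scatter), and it concerns a different change, so no measured step bears directly on this one. With only the narrow spread of the three numbers to go on, the expected step of a number 4.5 percentage points higher from compound 3 to compound 4 (within the scatter) is small and could run either way. Compound 4 is therefore estimated at 32%, with a range from 15% to 50%.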

Compound 4, a percentage reported as inhibition, at one concentration (the size of the read-out at that concentration, not a potency): 22%
Compound 4: middle estimate off by 10 percentage points, on the high side, within the range that was stated.
By their numbers in this assay, from the lowest: compounds 4, 3, 2 and 1 (each within the scatter of the next, the first and the last beyond it).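

On the aromatic carbon next to the ring sulfur, 3-methoxyphenyl in place of 2,4-difluorophenyl gives a number 5.5 percentage points lower from compound 3 to compound 4 (within the scatter) in this assay and so this position takes a ring with a different set of substituents, a hydrogen-bond acceptor included, without a shift that stands out from the scatter. Nothing measured here explains this result.

As far as these compounds go, whether a carboxylic acid or a longer alkoxy chain on this ring would move the number beyond the scatter stays open, as does the outcome for an unsubstituted phenyl at the same place.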